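Removing a hydrazine nitrogen from a weak growth inhibitor

This account rests on a few compounds, and the source may have more. Where it says the series, first, only, none or still open, it means among the compounds named here.

Compound 3 `Nc1nn2c(O)cc(CNNCCO)nc2c1[N+](=O)[O-]` was tested in a functional assay on L929 cells (Mus musculus) for inhibition; on this read-out higher numbers stand for weaker inhibition of growth and lower numbers for stronger inhibition of growth. In this assay compound 3 reaches only the limit > 50 ug/mL. Compound 1 `Nc1nn2c(O)cc(-c3ccccc3F)nc2c1[N+](=O)[O-]` likewise reaches only the limit > 50 ug/mL. Compound 2 `Nc1nn2c(O)cc(CNNc3ccc(F)cc3)nc2c1[N+](=O)[O-]` gives 41.4 ug/mL. The step that the two limits leave unreadable from compound 1 to compound 3 cannot be read, and the step of an at least 1.2-fold higher number from compound 2 to compound 3 (0.08 log units; that floor lies within the scatter) is small; both are shaped by the limit of > 50 ug/mL in this assay, at which 2 of the 3 values shown sit. Compound 4 `Nc1nn2c(O)cc(CNCCO)nc2c1[N+](=O)[O-]` differs from compound 3 by 2-hydroxyethyl in place of (2-hydroxyethyl)amino on an amine nitrogen. Going by the values given here, no measured step touches this part of the chain, so no direction beyond the scatter is expected. Compound 4 is therefore expected to sit near the limit as well, at an estimated 55 ug/mL between 25 ug/mL and 120 ug/mL. The expected step that the limit leaves unreadable from compound 3 to compound 4 is then close to none.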

Compound 4, concentration for 50% growth inhibition: > 50 ug/mL
Compound 4 was reported as a limit; the forecaster's own chance of this, stated with the estimate: 65%; the middle value does not contradict the limit.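

In this assay compound 4 gives > 50 ug/mL, which is a limit of the assay. Going by these compounds alone, the steps from compound 3 and from compound 1 to compound 4 cannot be read, and the one step with a floor, an at least 1.2-fold higher number from compound 2 to compound 4 (0.08 log units; that floor lies within the scatter), is small. Losing the hydrazine nitrogen therefore brings no sign of stronger inhibition of growth on this chain. Going by these compounds, whether compound 3 and compound 4 truly differ stays open because the values pile up at one point: the limit of > 50 ug/mL in this assay, at which 3 of the 4 values shown sit. Also open is how a longer chain, or one carrying a carboxylic acid, would read in place of 2-hydroxyethyl on the amine nitrogen.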